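The source may hold more compounds than are shown below. What is called first, only, known or untested is meant among the compounds shown, and "the series" means these compounds.

Compound 1 `CC(=O)Oc1ccccc1C(=O)O[C@H]1CO[C@H]2[C@@H]1OC[C@H]2O` gives 0.0183 h in an ADME assay on a cell-free system (plasma, Homo sapiens) for metabolic stability, with Plasma (Rattus norvegicus) as the target, read by HPLC, at pH 7.4 (on this read-out lower numbers stand for a shorter-lived compound and higher numbers for a longer-lived compound), the second highest of the three numbers in hand. Compound 2 `COc1ccccc1C(=O)O[C@@H]1CO[C@H]2[C@@H]1OC[C@@H]2OC(=O)c1ccccc1OC(C)=O` gives 0.0165 h and compound 3 `CC(=O)Oc1ccccc1C(=O)O[C@H]1CO[C@H]2[C@@H]1OC[C@H]2OC(=O)c1ccc([N+](=O)[O-])cc1` gives 0.0227 h; both lie within the scatter of compound 1. Compound 4 `CC(=O)Oc1ccccc1C(=O)O[C@H]1CO[C@H]2[C@@H]1OC[C@H]2OC(=O)c1cccnc1` differs from compound 1 by (pyridin-3-yl)carbonyl in place of hydrogen on an oxygen on a saturated carbon. Two measured steps replace the same hydrogen on the same oxygen of the shared core: a 1.1-fold lower number from compound 1 to compound 2 (0.04 log units; within the scatter) and a 1.2-fold higher number from compound 1 to compound 3 (0.09 log units; within the scatter). Neither left the scatter, and the step between the two compounds carrying a carbonyl group there, a 1.4-fold higher number from compound 2 to compound 3 (0.14 log units; within the scatter), also stayed within it. The expected step is therefore a 1.1-fold higher number from compound 1 to compound 4 (0.04 log units; within the scatter), no movement beyond the scatter. Compound 4 is estimated at 0.02 h in this assay, with a range of 0.012 h to 0.035 h.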

Compound 4, half-life: 0.00617 h
Beside the measured number, compound 4's estimate is 3.2-fold (0.51 log units) above it; measured number below the stated range.
By their numbers in this assay, from the lowest: compound 4; then compounds 2, 1 and 3 (each within the scatter of the next).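

At the oxygen on a saturated carbon, the acyl group is not interchangeable in this assay: (pyridin-3-yl)carbonyl in place of hydrogen gives a 3.0-fold lower number from compound 1 to compound 4 (0.47 log units; beyond the scatter), the first step from compound 1 beyond the scatter. The aryl group on the carbonyl carbon therefore counts here, with pyridin-3-yl giving a 3.7-fold lower number from compound 3 to compound 4 (0.57 log units; beyond the scatter) and a 2.7-fold lower number from compound 2 to compound 4 (0.43 log units; beyond the scatter). Nothing available bears on the cause of this shift.

As far as these compounds go, whether it follows the ring nitrogen or that nitrogen's place in the ring stays open, and plain phenyl or pyridin-4-yl on the carbonyl carbon would separate the two. Also open, from the compounds shown here alone, is which ester group of compound 4 is lost first.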